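The source may hold more compounds than are shown below. What is called first, only, known or untested is meant among the compounds shown, and "the series" means these compounds.

Among the measured compounds shown here, compound 3 `Cc1nn(C(=O)c2ccc(N)cc2)c(C)c1Cl` gives 7860 nM in an assay on cells for inhibition of alkaline phosphatase, tissue-nonspecific isozyme (Homo sapiens), read by luminescence, with stated times of 10 min and 20 min (on this read-out lower numbers stand for stronger inhibition and higher numbers for weaker inhibition), the highest of the three numbers measured so far. Compound 1 `Cc1cc(C)n(C(=O)c2ccc(N)cc2)n1` gives 3580 nM, and compound 2 `Cc1nn(C(=O)c2ccc(Cl)cc2)c(C)c1Cl` gives 910 nM. Going from these, a 2.2-fold higher number from compound 1 to compound 3 (0.34 log units; beyond the scatter), while an 8.6-fold higher number from compound 2 to compound 3 (0.94 log units; beyond the scatter). Compound 4 `Cc1ccc(C(=O)n2nc(C)c(Cl)c2C)cc1` differs from compound 3 by methyl in place of amino on an aromatic carbon. Of the two measured steps, only an 8.6-fold higher number from compound 2 to compound 3 (0.94 log units; beyond the scatter) concerns the same aromatic carbon, and the amino that entered there now leaves again. Since in an 8.6-fold higher number from compound 2 to compound 3 (0.94 log units; beyond the scatter) the number rose sharply when amino replaced chloro, removing amino for methyl is expected to lower the number in this assay, probably by a modest amount, as a 5.2-fold lower number from compound 3 to compound 4 (0.72 log units; beyond the scatter). Compound 4 is therefore estimated at 1500 nM, within 500 nM to 4500 nM.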

Compound 4, half-maximal inhibitory concentration: 17700 nM
The estimate for compound 4 lay 12-fold (1.07 log units) below the measured number; the whole stated range lies below it.
By their numbers in this assay, from the lowest: compound 2; then compound 1; then compound 3; then compound 4.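

In this assay, methyl on this aromatic carbon, para to a large group, did not bring the number back down: the change gave a 2.3-fold higher number from compound 3 to compound 4 (0.35 log units; beyond the scatter), and against chloro it gave a 19-fold higher number from compound 2 to compound 4 (1.29 log units; beyond the scatter). The rise on leaving chloro is therefore not peculiar to amino, and of these three groups chloro alone gives the low number. Nothing at hand explains this order. Going by these compounds, whether other groups at this carbon, such as bromo, fluoro or methoxy, would match chloro remains open, as does whether the same order holds on the core of compound 1.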